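The source may hold more compounds than are shown below. What is called first, only, known or untested is meant among the compounds shown, and "the series" means these compounds.

In a functional assay on MDA-MB-231 cells (Homo sapiens) for antiproliferative activity, with a stated time of 4 days (a lower number here means a stronger inhibitor, a higher number a weaker inhibitor), three compounds that differ in a single group on an aromatic carbon have been measured. The chloro compound 1 `CCCCc1ccc2[nH]c(-c3ccc(OC)cc3)c(/C=N/NC(=O)c3ccc(Cl)cc3)c2c1` gives 90 nM. The fluoro compound 2 `CCCCc1ccc2[nH]c(-c3ccc(OC)cc3)c(/C=N/NC(=O)c3ccc(F)cc3)c2c1` gives 19 nM. The nitro compound 3 `CCCCc1ccc2[nH]c(-c3ccc(OC)cc3)c(/C=N/NC(=O)c3ccc([N+](=O)[O-])cc3)c2c1` gives 115 nM.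

Fluoro in place of chloro brings a 4.7-fold lower number from compound 1 to compound 2 (0.68 log units; beyond the scatter). Nitro in place of chloro brings a 1.3-fold higher number from compound 1 to compound 3 (0.11 log units; within the scatter), and nitro in place of fluoro brings a 6.1-fold higher number from compound 2 to compound 3 (0.78 log units; beyond the scatter). Compound 3 therefore stands level with compound 1, and only compound 2 stands clearly lower.

The unmeasured compound 4 `CCCCc1ccc2[nH]c(-c3ccc(OC)cc3)c(/C=N/NC(=O)c3cccc(O)c3)c2c1` has 3-hydroxyphenyl in place of 4-nitrophenyl on a carbonyl carbon. Going by the values given here, no measured step introduces this group, so the three steps bear on it only loosely. They show how far swaps on this aromatic ring have moved the number, with a 6.1-fold higher number from compound 2 to compound 3 (0.78 log units; beyond the scatter) as the largest, but they give no direction for this change.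

In this assay, the expectation is therefore no shift beyond the scatter, an estimated 1.2-fold lower number from compound 3 to compound 4 (0.06 log units; within the scatter). For compound 4 the estimated value is 100 nM, with an expected range of 30 nM to 330 nM.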

Compound 4, half-maximal inhibitory concentration: 30 nM
Compound 4: the middle estimate sits 3.3-fold (0.52 log units) above what was measured; measured number inside the range.
By their numbers in this assay, from the lowest: compounds 2 and 4 (each within the scatter of the next); then compounds 1 and 3 (each within the scatter of the next).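

In this assay the change to 3-hydroxyphenyl gives a 3.8-fold lower number from compound 3 to compound 4 (0.58 log units; beyond the scatter) and also a 3.0-fold lower number from compound 1 to compound 4 (0.48 log units; beyond the scatter), so a ring with a hydroxy group in place of the earlier groups can hold a low number at this carbonyl carbon. Set against 4-fluorophenyl, the same change gives a 1.6-fold higher number from compound 2 to compound 4 (0.20 log units; within the scatter), which means two quite different rings stand level and 4-fluorophenyl is no longer alone in standing clearly below 4-chlorophenyl and 4-nitrophenyl. No evidence available here explains these differences.

Compound 4 changes both the group and where it sits on the ring, so the two effects cannot be told apart from these compounds. A 4-hydroxyphenyl ring would separate them, and a ring bearing an amine or a carboxylic acid would show how far this position tolerates other groups.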